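A few compounds are considered here, and "the series" means these few. Any claim that something is new, unique, unknown or untested is made for them only; others in the source may bear on it.

Three compounds have been measured in a functional assay on MCF7 cells (Homo sapiens) for cytotoxicity, read by CellTiter-Glo, with a stated time of 5 days; a lower number here means a stronger inhibitor, a higher number a weaker inhibitor:

Compound 1 `CC/C(=C(/c1ccc(/C=C/C(=O)O)cc1)c1ccc2[nH]c(=O)sc2c1)c1ccccc1`: 158 nM
Compound 2 `CC/C(=C(\c1ccc2[nH]ncc2c1)c1ccc(/C=C/C(=O)O)cc1C)c1ccccc1`: 36 nM
Compound 3 `CC/C(=C(/c1ccc(/C=C/C(=O)O)cc1)c1ccc2[nH]ncc2c1)c1cccc(Cl)c1`: 12 nM

Compound 3 gives the lowest of the three numbers. Compound 2 comes nearest, and its number is higher by an amount that lies beyond the usual scatter of the measurement, so compound 3 is the strongest of the three; compound 1 stands furthest away, with the highest number of the set.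

Compound 4 `CC/C(=C(/c1ccc(/C=C/C(=O)O)cc1)c1ccc2[nH]ncc2c1)c1ccncc1C` has not yet been measured. It differs from compound 3 in one place: 3-methylpyridin-4-yl in place of 3-chlorophenyl on a double-bonded chain carbon bound to a double-bonded chain carbon and a saturated chain carbon. Among the measured compounds shown here, no step between two measured compounds shows what such a swap does, so there is nothing to lean on directly; the three measured compounds differ from each other in several places at once.

For the measured compounds named here, with no direct precedent, a modest loss is expected in this assay, of roughly the size of the gap between compound 3 and compound 2, but the range must stay wide. For compound 4 the expected value is 30 nM, within 8 nM to 120 nM, which would be a step of a 2.5-fold higher number from compound 3 to compound 4 (0.40 log units; beyond the scatter).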

Compound 4, half-maximal inhibitory concentration: 16 nM
Estimate against measurement, compound 4: 1.9-fold (0.27 log units) above, within the range that was stated.
By their numbers in this assay, from the lowest: compounds 3 and 4 (each within the scatter of the next); then compound 2; then compound 1.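

In this assay, replacing 3-chlorophenyl with 3-methylpyridin-4-yl on this double-bonded chain carbon is a 1.3-fold higher number from compound 3 to compound 4 (0.12 log units; within the scatter), so the two compounds cannot be told apart. Among the compounds shown here, this place in the molecule therefore tolerates a ring with a nitrogen in it and a hydrogen-bond acceptor that 3-chlorophenyl lacks, something the earlier compounds, which differ in several places at once, could not show. Nothing available explains why the two groups give such similar numbers.

Going by these compounds, the swap removes the chlorine and brings in both the ring nitrogen and the methyl, so the contribution of each part remains unknown. Also open, on these data alone, is how pyridin-4-yl without the methyl, or a ring carrying a dimethylamino group, would behave at this carbon.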